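The source may hold more compounds than are shown below. What is called first, only, known or untested is meant among the compounds shown, and "the series" means these compounds.

Measured so far:
- compound 1, `C=C(Br)C(=O)Nc1cccc(-c2cn3nc(-c4ccc(F)cc4)sc3n2)c1`, gives 250 nM
- compound 2, `C=C(Br)C(=O)Nc1cccc(-c2cn3nc(-c4ccc(OCC)cc4)sc3n2)c1`, gives 790 nM
- compound 3, `C=C(Br)C(=O)Nc1cccc(-c2cn3nc(Cc4ccc(Cl)cc4)sc3n2)c1`, gives 2300 nM

All three were tested in a functional assay on L1210 cells (Mus musculus) for inhibition, read by cell counting, with a stated time of 2 days; on this read-out lower numbers stand for stronger inhibition and higher numbers for weaker inhibition. On these numbers compound 3 stands highest: from compound 2 the step is a 2.9-fold higher number from compound 2 to compound 3 (0.46 log units; beyond the scatter), and from compound 1 it is a 9.2-fold higher number from compound 1 to compound 3 (0.96 log units; beyond the scatter). The next compound, compound 4, `C=C(Br)C(=O)Nc1cccc(-c2cn3nc(-c4ccc(C)cc4)sc3n2)c1`, has not yet been measured. It differs from compound 3 in one place: 4-methylphenyl in place of 4-chlorobenzyl on an aromatic carbon.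

Among the compounds with values here, two measured steps bear on this change. Compound 1 and compound 2 both carry a phenyl group joined straight to the shared core, as compound 4 does, and both gave lower numbers than compound 3, where a 4-chlorobenzyl sits in that place. Going the other way, from a 4-chlorobenzyl back to a phenyl group bearing a small substituent, a drop is therefore expected, of a size between those two steps. The estimate for compound 4 is 400 nM, within 150 nM to 1200 nM, which would mean an expected step of a 5.8-fold lower number from compound 3 to compound 4 (0.76 log units; beyond the scatter).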

Compound 4, half-maximal inhibitory concentration: 920 nM
For compound 4 the middle estimate is 2.3-fold (0.36 log units) below the measured one; measured number inside the range.
By their numbers in this assay, from the lowest: compound 1; then compounds 2 and 4 (each within the scatter of the next); then compound 3.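

In this assay, 4-methylphenyl in place of 4-chlorobenzyl on this aromatic carbon gives a drop (a 2.5-fold lower number from compound 3 to compound 4 (0.40 log units; beyond the scatter)), so all three compounds with a phenyl ring joined straight to the shared core now have lower numbers than the one with the 4-chlorobenzyl. On that phenyl ring, methyl in place of ethoxy gives a 1.2-fold higher number from compound 2 to compound 4 (0.07 log units; within the scatter) and so no real difference, whereas methyl in place of fluoro gives a clear rise (a 3.7-fold higher number from compound 1 to compound 4 (0.57 log units; beyond the scatter)). The fluoro compound, compound 1, therefore stands apart from the methyl and ethoxy compounds, which cannot be told apart here.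

On these data alone, how an amine, a carboxylic acid or a longer chain on that ring would fare remains open, as does whether a 4-chlorophenyl would separate the effect of the extra carbon in the 4-chlorobenzyl from that of the chlorine. No measurement shown here explains any of these differences.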